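Urea in Place of Amide on a Shared Biaryl Core

The source may hold more compounds than are shown below. What is called first, only, known or untested is meant among the compounds shown, and "the series" means these compounds.

Compound 3 `CCNC(=O)c1cccc(-c2ccc(OCC)cc2)c1` gives 62% in an assay on COS-7 cells for inhibition of patatin-like phospholipase domain-containing protein 2 (Mus musculus), tested at 200 uM (a higher number here means more inhibition at the concentration tested (going by the name of the read-out), a lower number less inhibition), the second highest of three numbers. Its nearest neighbour is compound 1 `CCOc1ccc(-c2cccc(S(=O)(=O)N(C)C)c2)cc1` with 63%; the step of a number 1 percentage points lower from compound 1 to compound 3 (within the scatter) lies within the scatter. Compound 2 `CCOc1ccc(-c2cccc(S(=O)(=O)NC)c2)cc1` gives 47%, and the step of a number 15 percentage points higher from compound 2 to compound 3 (beyond the scatter) is beyond the scatter. Compound 4 `CCOc1ccc(-c2cccc(NC(=O)N(C)C)c2)cc1` differs from compound 3 by (dimethylcarbamoyl)amino in place of ethylcarbamoyl on an aromatic carbon. Among the compounds with values here, no measured step replaces the amide with a urea. The closest guide is a number 1 percentage points lower from compound 1 to compound 3 (within the scatter), where exchanging the group on that aromatic carbon left inhibition within the scatter, whereas a number 16 percentage points lower from compound 1 to compound 2 (beyond the scatter) shows that hydrogen in place of methyl on a sulfonamide nitrogen lowered it modestly. Compound 4 is therefore expected to show a step of a number 7 percentage points lower from compound 3 to compound 4 (within the scatter), an estimate of 55% ranging from 35% to 75%.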

Compound 4, a percentage reported as inhibition, at one concentration (the size of the read-out at that concentration, not a potency): 68%
Compound 4: the middle estimate sits 13 percentage points below what was measured; measured number inside the range.
By their numbers in this assay, from the lowest: compound 2; then compounds 3, 1 and 4 (each within the scatter of the next).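

In this assay, (dimethylcarbamoyl)amino proves interchangeable with ethylcarbamoyl on this aromatic carbon, with a number 6 percentage points higher from compound 3 to compound 4 (within the scatter), and with dimethylsulfamoyl, with a number 5 percentage points higher from compound 1 to compound 4 (within the scatter). Only the methylsulfamoyl compound stands apart, with a number 21 percentage points higher from compound 2 to compound 4 (beyond the scatter), so a urea joins the amide and the dimethylsulfonamide at this position as a group that keeps inhibition at the same level. Nothing available explains these steps. As far as these compounds go, whether a urea bearing a longer chain, a plain amine or a carboxylic acid on this carbon would keep that level stays open. So does whether the urea's hydrogen matters.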